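A few compounds are considered here, and "the series" means these few. Any claim that something is new, unique, unknown or untested is made for them only; others in the source may bear on it.

Going by the values given here, compound 1, `COc1cc(C(c2ccc(O)c(OC)c2)[C@@H](C)[C@H](C)CF)ccc1O`, is the only member of this small set with a measured number: in a functional assay on HeLa cells (Homo sapiens) for cytotoxicity, read by WST assay, with a stated time of 48 h (on this read-out lower numbers stand for stronger inhibition and higher numbers for weaker inhibition), compound 1 gives 37000 nM. Compound 2, `COc1cc(C(c2ccc(O)c(OC)c2)[C@H](CO)C(C)C)ccc1O`, reaches only a limit of the assay, and in this assay compound 2 gives > 100000 nM. Compound 3, `COc1cc(C(c2ccc(O)c(OC)c2)[C@H](C)[C@@H](C)CO)ccc1O`, likewise stops at a limit, giving > 100000 nM in this assay. The two steps away from compound 1 therefore read as an at least 2.7-fold higher number from compound 1 to compound 2 (0.43 log units; beyond the scatter) and an at least 2.7-fold higher number from compound 1 to compound 3 (0.43 log units; beyond the scatter), each ending at the limit of > 100000 nM in this assay, at which 2 of the 3 values shown sit. Compound 4, `CC[C@H](C(C)C)C(c1ccc(O)c(OC)c1)c1ccc(O)c(OC)c1`, is not yet measured; it differs from compound 1 by 1-isopropylpropyl in place of 2-(fluoromethyl)-1-methylpropyl on a saturated chain carbon bound to two aromatic carbons. Both measured steps place a 1-(hydroxymethyl)-2-methylpropyl or 2-(hydroxymethyl)-1-methylpropyl group at that position, whereas compound 4 carries a 1-isopropylpropyl group there, so neither step mirrors the change closely. The set gives no reason to assume a loss, and none to expect a gain. Compound 4 is therefore expected to give a number close to the one measured first, a step of a 1.1-fold higher number from compound 1 to compound 4 (0.03 log units; within the scatter), with an estimate of 40000 nM and a range from 15000 nM to 100000 nM.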

Compound 4, half-maximal inhibitory concentration: 9700 nM
For compound 4 the middle estimate is 4.1-fold (0.62 log units) above the measured one; measured number below the stated range.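

Compound 4 shows that this position, a saturated chain carbon bound to two aromatic carbons, can give a lower number with an all-carbon group: in this assay, 1-isopropylpropyl in place of 2-(fluoromethyl)-1-methylpropyl gives a 3.8-fold lower number from compound 1 to compound 4 (0.58 log units; beyond the scatter). The gap to the hydroxymethyl-bearing chains is wider, with an at least 10-fold lower number from compound 3 to compound 4 (1.01 log units; beyond the scatter) and, for methyl in place of hydroxy, an at least 10-fold lower number from compound 2 to compound 4 (1.01 log units; beyond the scatter). Both of these steps start from a limit of the assay, not a number: the limit of > 100000 nM in this assay, at which 2 of the 4 values shown sit.

The step from compound 1 changes both the fluorine and the branching of the chain, so the compounds shown do not separate the two. Going by these compounds, it also remains open how a longer alkyl chain, a cyclohexyl ring, an amine or a carboxylic acid would read at this position.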